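Swapping Isopropyl for Methyl on an Inactive Core

The source may report more compounds than this note shows. Statements on the series, on what has been measured and on what is new or still open speak of the compounds shown alone.

The measured compounds and their values in a functional assay for inhibition, with Homo sapiens as the target; a lower number here means a stronger inhibitor, a higher number a weaker inhibitor:
compound 1 `COCc1nc(C)c2c(C)nnc(O)n12` gives > 48000 nM;
compound 2 `CC(C)c1ncn2c(Nc3cc[nH]n3)nccc12` gives > 48000 nM;
compound 3 `CCCc1nc(Br)c2c(Br)nnc(O)n12` gives 48000 nM.

For compound 2 the value is only a limit of the assay, not a number. For compound 1 the value is likewise a limit. Among the compounds with values here, compound 3 is the one compound with an actual number, and that number sits exactly at the boundary where the other two are reported as limits, so all three compounds are weak in this assay and no one of them can be called stronger or weaker than another. The picture is summed up by the limit of > 48000 nM in this assay, at which 2 of the 3 values shown sit. No pair of these compounds differs in a single place, so no measured step is available.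

The next compound, compound 4 `Cc1ncn2c(Nc3cc[nH]n3)nccc12`, differs from compound 2 by methyl in place of isopropyl on an aromatic carbon. Since compound 2 sits at a limit, the step from compound 2 to compound 4 in this assay is expected to be none beyond the scatter, so that a step that the limit leaves unreadable from compound 2 to compound 4 is the estimated change. Compound 4 is therefore expected to give about 60000 nM, with a range from 30000 nM to 150000 nM, and most likely to be reported once more as a limit rather than a number.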

Compound 4, half-maximal inhibitory concentration: 57000 nM
Estimate against measurement, compound 4: 1.1-fold (0.02 log units) above, and the stated range covers the measured number.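

Compound 2 is reported only as a limit, not a number, so no step from compound 2 to compound 4 can be read, because the size of that change stays hidden behind the limit: the limit of > 48000 nM in this assay, at which 2 of the 4 values shown sit.

The compounds shown leave open whether swapping isopropyl for methyl at this place changes inhibition at all.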